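Varying the aroyl amide on a shared thiourea core

The source may hold more compounds than are shown below. What is called first, only, known or untested is meant among the compounds shown, and "the series" means these compounds.

Measured so far in this assay:
compound 1, `NC(=O)c1c(NC(=O)c2ccccc2F)sc2c1CCN(C(=S)Nc1cc(C(F)(F)F)cc(C(F)(F)F)c1)C2`, 17900 nM
compound 2, `NC(=O)c1c(NC(=O)c2ccc(C(F)(F)F)cc2)sc2c1CCN(C(=S)Nc1cc(C(F)(F)F)cc(C(F)(F)F)c1)C2`, 16300 nM

In a functional assay on HL-60 cells (Homo sapiens) for antiproliferative activity, with a stated time of 24 h (on this read-out lower numbers stand for stronger inhibition and higher numbers for weaker inhibition), compound 1 gives 17900 nM, and compound 2 gives 16300 nM. Compound 2 has the lowest of the two numbers, but its distance from compound 1 lies within the scatter, so the two cannot be ranked. Among the compounds with values here, the only measured step, a 1.1-fold lower number from compound 1 to compound 2 (0.04 log units; within the scatter), exchanged the aryl group on the amide carbonyl carbon and left the number essentially unchanged.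

Compound 3, `NC(=O)c1c(NC(=O)c2cccc([N+](=O)[O-])c2)sc2c1CCN(C(=S)Nc1cc(C(F)(F)F)cc(C(F)(F)F)c1)C2`, differs from compound 2 by 3-nitrophenyl in place of 4-(trifluoromethyl)phenyl on a carbonyl carbon. The step from compound 1 to compound 2 is the one that bears on this change, since it also swapped the aryl group on that carbonyl carbon, and it was within the scatter. Compound 3 is therefore expected to show no step beyond the scatter in this assay, an estimated 1.0-fold higher number from compound 2 to compound 3 (0.02 log units; within the scatter). For compound 3 the expected value is 17000 nM, with a range from 7000 nM to 40000 nM.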

Compound 3, half-maximal inhibitory concentration: 16400 nM
For compound 3 the middle estimate is 1.0-fold (0.02 log units) above the measured one, and the stated range covers the measured number.
By their numbers in this assay, from the lowest: compounds 2, 3 and 1 (each within the scatter of the next).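

In this assay a third aryl group on the carbonyl carbon again leaves the number within the scatter, with a 1.0-fold higher number from compound 2 to compound 3 (0.00 log units; within the scatter) and a 1.1-fold lower number from compound 1 to compound 3 (0.04 log units; within the scatter) as well. The earlier comparison covered fluorine- and trifluoromethyl-bearing phenyl groups. The same now holds for 3-nitrophenyl, which brings nitrogen, oxygen and 2 hydrogen-bond acceptors to this position, and compound 1, compound 2 and compound 3 still cannot be ranked. Nothing measured here bears on why these three groups read alike.

As far as these compounds go, all three groups at this position are substituted phenyl rings, so it remains open whether a phenyl ring carrying an amine or a carboxylic acid, or a cyclohexyl ring or longer alkyl chain in place of the ring, would move the number beyond the scatter. The compounds shown also leave open how far the number depends on the rest of the shared core.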